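Ethoxycarbonyl to carboxy in two cores: cytotoxicity notes

The source may report more compounds than this note shows. Statements on the series, on what has been measured and on what is new or still open speak of the compounds shown alone.

Compound 1 `CCOC(=O)c1ccc(SCc2ccc3nc(OC)c(OC)nc3c2)cc1` and compound 2 `COc1nc2ccc(CSc3ccc(C(=O)O)cc3)cc2nc1OC` share a core and differ by hydrogen in place of ethyl on an oxygen next to a carbonyl group. In an ADME assay on MT4 cells (Homo sapiens) for cytotoxicity, read by MTT assay, with a stated time of 96 h (a higher number here means that more compound is tolerated, a lower number that less compound is tolerated), compound 1 gives only a limit, > 100000 nM. Compound 2 gives 68000 nM in this assay. The step of an at least 1.4-fold lower number from compound 1 to compound 2 (0.16 log units; that floor lies within the scatter) is a floor only, because compound 1 sits at the limit of > 100000 nM in this assay, at which 2 of the 3 values shown sit.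

Compound 3 `CCOC(=O)c1ccc(SCc2ccc3nc(OC)c(OC)nc3c2)nc1` carries a different core; the difference between the two cores is not broken down here. In this assay compound 3 gives only a limit, > 100000 nM. Compound 4 `COc1nc2ccc(CSc3ccc(C(=O)O)cn3)cc2nc1OC` differs from compound 3 by hydrogen in place of ethyl on an oxygen next to a carbonyl group, the same kind of change as from compound 1 to compound 2.

For compound 4 a step of an at least 1.1-fold lower number from compound 3 to compound 4 (0.04 log units; that floor lies within the scatter) is expected in this assay, resting on the small floor seen in an at least 1.4-fold lower number from compound 1 to compound 2 (0.16 log units; that floor lies within the scatter). Compound 4 is estimated at 90000 nM, between 40000 nM and 200000 nM.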

Compound 4, half-maximal cytotoxic concentration: > 100000 nM
Compound 4 was reported as a limit; the forecaster's own chance of this, stated with the estimate: 50%; at least 1.1-fold (0.04 log units) between middle value and limit.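

No step from compound 3 to compound 4 can be read in this assay, since both compounds are reported only as limits: the limit of > 100000 nM in this assay, at which 3 of the 4 values shown sit.

The compounds shown leave open how large the ethoxycarbonyl to carboxy change is in the core of compound 3.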